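Ethyl Ester to Methyl Ester in Compound 3

The compounds below may be only part of what the source reports. "The series", "measured", "known", "first", "only" and "open" are said of these compounds alone.

Measured compounds:
compound 1 `COc1ccc(-c2ccc3c(c2)C(=O)C(=O)N3Cc2ccc(Cl)cc2)cc1` — 250 nM
compound 2 `CCOC(=O)/C=C1\C(=O)N(Cc2ccc(OC)cc2)c2ccc(-c3ccc(OC)cc3)cc21` — 3390 nM

Both compounds were tested in a functional assay on HepG2 cells (Homo sapiens) for antiproliferative activity, read by MTT assay, with a stated time of 48 h; on this read-out lower numbers stand for stronger inhibition and higher numbers for weaker inhibition. In this assay compound 1 gives 250 nM, while compound 2 gives 3390 nM. Compound 2 therefore stands at the higher of the two numbers, and its gap to compound 1 lies well beyond the usual scatter of repeated measurements.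

Compound 3 `COC(=O)/C=C1\C(=O)N(Cc2ccc(OC)cc2)c2ccc(-c3ccc(OC)cc3)cc21` differs from compound 2 in one place only: hydrogen in place of methyl on a saturated chain carbon bound to an oxygen next to a carbonyl group. Among the compounds with values here, no measured pair in this set carries the same change, so the expected size of the step rests on the change alone. The trimming of the ester chain by one carbon is expected to leave the number essentially where it is, and the step from compound 2 to compound 3 is expected to be a 1.1-fold lower number from compound 2 to compound 3 (0.05 log units; within the scatter), within the scatter. Compound 3 is accordingly estimated at 3000 nM, with a range from 1200 nM to 7500 nM.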

Compound 3, half-maximal inhibitory concentration: 4730 nM
The estimate for compound 3 lay 1.6-fold (0.20 log units) below the measured number, and the stated range covers the measured number.
By their numbers in this assay, from the lowest: compound 1; then compounds 2 and 3 (each within the scatter of the next).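

Within the data shown here, compound 2 and compound 3 form the first pair here that differs in one place, so this is the first direct reading of any change on the ester. In this assay, the change from ethoxycarbonyl to methoxycarbonyl gives a 1.4-fold higher number from compound 2 to compound 3 (0.14 log units; within the scatter), which means that removing this one carbon does not separate the two compounds. This holds only for this pair, and no measurement offered here accounts for the result.

The compounds shown leave open whether a longer chain such as propyl or butyl on this oxygen, or a carboxylic acid or an amide in place of the ester, would stay in the same range. As far as these compounds go, they also show this change only on the core of compound 2, so its outcome on other cores remains unknown.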